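Swapping the benzyl substituent on a rhodanine-type scaffold

A few compounds are considered here, and "the series" means these few. Any claim that something is new, unique, unknown or untested is made for them only; others in the source may bear on it.

Measured so far:
compound 1, `C=C(Br)C(=O)Nc1cccc(/C=C2\SC(=O)N(Cc3ccc(C)cc3)C2=O)c1`, 1200 nM
compound 2, `CC(C)(C)c1ccc(CN2C(=O)S/C(=C\c3ccc(N)cc3)C2=O)cc1`, 53000 nM
compound 3, `C=C(Br)C(=O)Nc1ccc(/C=C2\SC(=O)N(Cc3cccc(F)c3)C2=O)cc1`, 5900 nM

In a functional assay on HeLa cells (Homo sapiens) for cytotoxicity, read by cell counting, with a stated time of 4 days (a higher number here means a weaker inhibitor, a lower number a stronger inhibitor), compound 3 gives 5900 nM, the second highest of the three numbers. Its nearest neighbour is compound 1, whose value is lower by a margin beyond the scatter; furthest away is compound 2, which lacks the bromoacrylamide altogether and gives a number higher than compound 3, again beyond the scatter.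

Compound 4, `C=C(Br)C(=O)Nc1ccc(/C=C2\SC(=O)N(Cc3ccc(C)cc3)C2=O)cc1`, is not yet measured. It differs from compound 3 in one place: 4-methylphenyl in place of 3-fluorophenyl on a saturated chain carbon bound to an amide-type nitrogen in a ring. Among the compounds with values here, no measured pair shows this exact swap on its own. Compound 1 carries the same 4-methylbenzyl group as compound 4 but differs from it elsewhere, so the comparison is indirect. On that basis the step from compound 3 to compound 4 is expected to be modest, with the number moving somewhat lower, though a result within the scatter would not surprise; the expected step is a 1.7-fold lower number from compound 3 to compound 4 (0.23 log units; within the scatter). Compound 4 is therefore estimated at 3500 nM, within a range from 1200 nM to 10000 nM.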

Compound 4, half-maximal inhibitory concentration: 8900 nM
Compound 4: the middle estimate sits 2.5-fold (0.41 log units) below what was measured, and the stated range covers the measured number.
By their numbers in this assay, from the lowest: compound 1; then compounds 3 and 4 (each within the scatter of the next); then compound 2.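

In this assay, putting 4-methylphenyl in place of 3-fluorophenyl on the saturated chain carbon bound to the amide-type nitrogen in a ring gives a 1.5-fold higher number from compound 3 to compound 4 (0.18 log units; within the scatter), so with the rest of compound 3 held fixed, these two benzyl groups cannot be told apart at this position. The 4-methylbenzyl group alone therefore does not bring a number as low as that of compound 1, 1200 nM, since compound 4, which carries the same group, stands at 8900 nM. No evidence is available that would explain this result.

The compounds shown leave open whether the fluorine and the methyl group matter separately, since the exchange alters both the substituent and its place on the ring, and 4-fluorobenzyl or 3-methylbenzyl would be needed to pull these apart. They also leave open whether this position stays as indifferent to groups of another kind, such as an amine or a carboxylic acid on the benzyl ring, or a longer chain in place of the benzyl group.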